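Benzyl in place of pyridin-2-yl on the amide nitrogen

This account rests on a few compounds, and the source may have more. Where it says the series, first, only, none or still open, it means among the compounds named here.

Compound 1 `Cc1cc(C(=O)Nc2ccccc2)nn1Cc1cc(Cl)ccc1OCc1ccccc1`: > 3.7, a limit of this assay
Compound 2 `Cc1cc(C(=O)Nc2ccc(F)cc2)nn1Cc1cc(Cl)ccc1OCc1ccccc1`: 3
Compound 3 `Cc1cc(C(=O)Nc2ccccn2)nn1Cc1cc(Cl)ccc1OCc1ccccc1`: > 3.7, a limit of this assay

In a physicochemical assay for lipophilicity, at pH 7.4 (a lower number here means a more polar compound, a higher number a more lipophilic compound), compound 3 gives only a limit, > 3.7. Two of the three measured values sit at the limit of > 3.7 in this assay, at which 2 of the 3 values shown sit, so compound 3 stands at the top of what the assay reports. Compound 4 `Cc1cc(C(=O)NCc2ccccc2)nn1Cc1cc(Cl)ccc1OCc1ccccc1` differs from compound 3 by benzyl in place of pyridin-2-yl on an amide-type nitrogen. Within the data shown here, two measured steps touch the pyridin-2-yl amide: a number at least 0.70 log units higher from compound 2 to compound 3 (beyond the scatter), whereas a step that the two limits leave unreadable from compound 1 to compound 3. Both point to the pyridin-2-yl amide lying high, and the change to benzyl is not expected to bring compound 4 back into readable range. The step that the limit leaves unreadable from compound 3 to compound 4 is therefore expected to be small or unreadable. Compound 4 is estimated at 4.2, between 3.7 and 4.8.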

Compound 4, distribution coefficient: > 3.7
Compound 4: only a limit was reported (the forecaster's own chance of this, stated with the estimate: 85%); the middle value does not contradict the limit.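

In this assay compound 4 gives > 3.7, which is a limit of the assay, so benzyl on the amide-type nitrogen yields no number, just as phenyl and pyridin-2-yl did. Among these compounds, the one readable step is a number at least 0.70 log units higher from compound 2 to compound 4 (beyond the scatter), while the steps from compound 1 and compound 3 to compound 4 cannot be read. Compound 2, with 4-fluorophenyl, thus remains the only compound with a readable value: the limit of > 3.7 in this assay, at which 3 of the 4 values shown sit.

Going by these compounds, how far apart compound 1, compound 3 and compound 4 truly lie stays open. Also open, on these data alone, is whether an amine or a carboxylic acid in place of benzyl on the amide-type nitrogen would give a readable value in this assay.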